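Vero cell tolerance on removing a methoxy group

The source may report more compounds than this note shows. Statements on the series, on what has been measured and on what is new or still open speak of the compounds shown alone.

For the measured compounds named here, compound 1 `O=C(/C=C/c1ccc(F)cc1)O/C(=N/C1CCCCC1)NC1CCCCC1` and compound 2 `COC(=O)c1coc(/C=C/c2ccc(OC)cc2)n1` are the two members so far read in an ADME assay on Vero cells (Chlorocebus sabaeus) for cytotoxicity, read by WST assay, tested at 100 ug/mL; a higher number here means a weaker effect of the compound at the concentration tested, a lower number a stronger effect. In this assay compound 1 gives 85.5%, while compound 2 gives 96.8%. Compound 2 thus stands highest of the two numbers, and its nearest neighbour, compound 1, lies lower by a margin beyond the scatter. Going by the values given here, the two compounds share no single-point relation, so no step between measured compounds is available.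

Compound 3 `COC(=O)c1coc(/C=C/c2ccccc2)n1` is the next candidate for this assay. It differs from compound 2 by hydrogen in place of methoxy on an aromatic carbon. Among the compounds with values here, no measured pair shows this change, so the direction of its effect is unknown; the step from compound 2 to compound 3 is expected to be small, with no change beyond the scatter, as a number 2.8 percentage points lower from compound 2 to compound 3 (within the scatter). Compound 3 is accordingly expected to give 94% in this assay, within a range from 82% to 100%.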

Compound 3, a percentage reported as activity, at one concentration (the size of the read-out at that concentration, not a potency): 102%
Compound 3: the middle estimate sits 8 percentage points below what was measured, and the stated range ends below it.
By their numbers in this assay, from the lowest: compound 1; then compounds 2 and 3 (each within the scatter of the next).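

For the compounds shown here, the step is the first single-point comparison. In this assay, hydrogen in place of methoxy, on an aromatic carbon para to a large group, gives a number 5.2 percentage points higher from compound 2 to compound 3 (within the scatter). At this position, then, the methoxy group can be removed with no change that this read-out can distinguish at the one concentration tested, and compounds 2 and 3 stand as equals here. No supporting measurement bears on this result.

Going by these compounds, whether an amine or a chlorine atom at the same place would also stay within the scatter of compound 3 remains open. Also open, on these data alone, is what a carboxylic acid in place of the methyl ester on the shared core would give in this assay.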